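Series notes: anilino replacement of the enol hydroxy in compound 1

A few compounds are considered here, and "the series" means these few. Any claim that something is new, unique, unknown or untested is made for them only; others in the source may bear on it.

Compound 1 `O=C(C1=C(O)C(=O)N(CCCn2ccnc2)C1c1ccc(Br)cc1)c1ccccc1` gives 73100 nM in a functional assay on A549 cells (Homo sapiens) for antiproliferative activity, read by MTT assay, with a stated time of 72 h (on this read-out lower numbers stand for stronger inhibition and higher numbers for weaker inhibition), and stands highest of the two numbers recorded there; compound 2 `CCOC1=C(C(=O)c2ccccc2)C(c2ccc(Br)cc2)N(CCCn2ccnc2)C1=O` gives 35300 nM and compound 3 `NC1=C(C(=O)c2ccccc2)C(c2ccc(Br)cc2)N(CCCn2ccnc2)C1=O` is reported as "not active" (no number reported). For the measured compounds named here, the only step at this position, a 2.1-fold lower number from compound 1 to compound 2 (0.32 log units; beyond the scatter), is a modest one. Compound 4 `O=C(C1=C(Nc2ccc(Cl)cc2)C(=O)N(CCCn2ccnc2)C1c1ccc(Br)cc1)c1ccccc1` carries (4-chlorophenyl)amino in place of hydroxy on a double-bonded ring carbon. Compound 3, with the same hydroxy exchanged for an amine, shows no measurable number, whereas the ether in compound 2 shows a small gain; the present change has no direct precedent among these measurements. Taking both observations together, compound 4 is expected to land near compound 1, the step of a 1.1-fold higher number from compound 1 to compound 4 (0.04 log units; within the scatter) likely within or barely beyond the scatter, with a real chance of no reportable number. The estimate for compound 4 is 80000 nM, range 20000 nM to 300000 nM.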

Compound 4, half-maximal inhibitory concentration: 30000 nM
Estimate against measurement, compound 4: 2.7-fold (0.43 log units) above, and the stated range covers the measured number.
By their numbers in this assay, from the lowest: compounds 4 and 2 (each within the scatter of the next); then compound 1.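

In this assay, (4-chlorophenyl)amino in place of hydroxy gives a measurable number and a modest gain (a 2.4-fold lower number from compound 1 to compound 4 (0.39 log units; beyond the scatter)), whereas the amine of compound 3 gave no number. Against the ether, the change stays within the scatter (a 1.2-fold lower number from compound 2 to compound 4 (0.07 log units; within the scatter)), so ethoxy and (4-chlorophenyl)amino cannot be told apart at this position. No measured evidence accounts for this result.

Still open, on these data alone, is how phenylamino without the chlorine, or benzylamino, would read here. Whether the chlorine contributes at all also remains unsettled.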